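From Chloro to Hydroxy: Estimating Compound 4

This account rests on a few compounds, and the source may have more. Where it says the series, first, only, none or still open, it means among the compounds named here.

In a functional assay on NCI-H460 cells (Homo sapiens) for inhibition, read by MTT assay, with a stated time of 72 h (a lower number here means a stronger inhibitor, a higher number a weaker inhibitor), compound 1 (`COc1cc(NC(C)CCCNC(=O)NNC(=O)Nc2ccc(Br)cc2)c2ncccc2c1`) gives 27000 nM, compound 2 (`COc1cc(NC(C)CCCNC(=O)Nc2cccc(C(F)(F)F)c2)c2ncccc2c1`) gives 21000 nM and compound 3 (`COc1cc(NC(C)CCCNC(=O)Nc2ccc(Cl)cc2)c2ncccc2c1`) gives 34000 nM. These three values lie within the usual scatter of one another, so compound 3 stands level with the other two. Compound 4 (`COc1cc(NC(C)CCCNC(=O)Nc2ccc(O)cc2)c2ncccc2c1`) carries hydroxy in place of chloro on an aromatic carbon, para to a large group: hydroxy in place of chloro on an aromatic carbon. Swaps of the whole group on the amide-type nitrogen gave a 1.6-fold higher number from compound 2 to compound 3 (0.21 log units; within the scatter) and a 1.3-fold higher number from compound 1 to compound 3 (0.10 log units; within the scatter), both within the scatter. Among the measured compounds shown here, no measured compound carries hydroxy, so this evidence is indirect. In this assay the expected step is a 1.0-fold higher number from compound 3 to compound 4 (0.01 log units; within the scatter), which means no change beyond the scatter is expected. For compound 4 the estimated value is 35000 nM, with an expected range of 14000 nM to 80000 nM.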

Compound 4, half-maximal inhibitory concentration: 34000 nM
The estimate for compound 4 lay 1.0-fold (0.01 log units) above the measured number; low and high end bracket the measured number.
By their numbers in this assay, from the lowest: compounds 2, 1, 3 and 4 (each within the scatter of the next).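

In this assay, hydroxy in place of chloro on an aromatic carbon, para to a large group, brings in a hydrogen-bond donor and a hydrogen-bond acceptor, yet the result is no change at the digits printed from compound 3 to compound 4 (within the scatter). Compound 4 also stands level with the two compounds that differ on the amide-type nitrogen, with a 1.6-fold higher number from compound 2 to compound 4 (0.21 log units; within the scatter) and with a 1.3-fold higher number from compound 1 to compound 4 (0.10 log units; within the scatter). Nothing measured here offers an explanation for this flat result. As far as these compounds go, whether an amine or a carboxylic acid at this position would read differently stays open. So does whether any change here can move the number beyond the scatter.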